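From isopropyl to hydroxymethyl on an aromatic nitrogen

This account rests on a few compounds, and the source may have more. Where it says the series, first, only, none or still open, it means among the compounds named here.

Measured so far in a functional assay on NCI-H460 cells (Homo sapiens) for inhibition, with a stated time of 72 h; a lower number here means a stronger inhibitor, a higher number a weaker inhibitor:
- compound 1 `CCCn1ccc2cc(C(=O)c3cc(OC)c(OC)c(OC)c3)ccc21` gives 2000 nM
- compound 2 `COc1cc(C(=O)c2ccc3c(ccn3C(C)C)c2)cc(OC)c1OC` gives 1600 nM

Among the measured compounds shown here, compound 2, at 1600 nM, stands level with compound 1 within the scatter, and these two numbers are all that is known in this assay so far. Neither compound can be ranked above the other.

The next compound to be tested is compound 3 `COc1cc(C(=O)c2ccc3c(ccn3CO)c2)cc(OC)c1OC`, which keeps the shared core and carries hydroxymethyl in place of isopropyl on an aromatic nitrogen.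

For the measured compounds named here, only one measured step bears on this change. That step, a 1.3-fold lower number from compound 1 to compound 2 (0.10 log units; within the scatter), exchanges propyl for isopropyl at the same aromatic nitrogen and stays within the scatter. Going by the values given here, it offers only weak guidance, since no measured compound carries hydroxymethyl there and the data give no direction for such a swap. The expected change is therefore a 1.1-fold lower number from compound 2 to compound 3 (0.06 log units; within the scatter), which would be no real shift beyond the scatter. In this assay the estimate for compound 3 is 1400 nM, with an expected range from 400 nM to 6000 nM, kept wide for this untested group.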

Compound 3, half-maximal inhibitory concentration: 39 nM
Compound 3: the middle estimate sits 36-fold (1.56 log units) above what was measured; the whole stated range lies above it.
By their numbers in this assay, from the lowest: compound 3; then compounds 2 and 1 (each within the scatter of the next).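

In this assay, this position on the aromatic nitrogen proves far from indifferent: hydroxymethyl in place of isopropyl gives a 41-fold lower number from compound 2 to compound 3 (1.61 log units; beyond the scatter), and hydroxy in place of ethyl on the saturated chain carbon bound to that nitrogen gives a 51-fold lower number from compound 1 to compound 3 (1.71 log units; beyond the scatter). Propyl and isopropyl had shown only a 1.3-fold lower number from compound 1 to compound 2 (0.10 log units; within the scatter), so the two alkyl groups alone gave no sign that a change here could move the number beyond the scatter, whereas hydroxymethyl, with its oxygen, its hydrogen-bond donor and its hydrogen-bond acceptor, marks the first large step at this position. Nothing measured here accounts for the size of this step.

Compound 3 differs from compound 2 both in the size of the group and in the presence of the oxygen, which leaves open which of the two goes with the lower number. On these data alone, how a methyl group, a methoxymethyl group or a longer chain such as hydroxyethyl would stand on this nitrogen also remains open, and any of these would help to separate the two.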